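The source may report more compounds than this note shows. Statements on the series, on what has been measured and on what is new or still open speak of the compounds shown alone.

In an ADME assay on the whole organism with Oryza sativa as the target, tested at 0.1 uM (a higher number here means a weaker effect of the compound at the concentration tested, a lower number a stronger effect), compound 1 `CCCc1ccc(NC(=O)N[C@H](C)c2ccccc2)cc1` gives 33%, compound 2 `CCOC(=O)c1cccc(NC(=O)N[C@H](C)c2ccccc2)c1` gives 99% and compound 3 `CCOC(=O)c1cccc(NC(=O)N[C@@H](C)c2ccccc2)c1` gives 100%. Compound 2 stands second highest of the three, with compound 3 nearest and compound 1 furthest, the latter beyond the scatter. Going by the values given here, the only single step measured, a number 1 percentage points higher from compound 2 to compound 3 (within the scatter), lies within the scatter, consistent with the fact that compounds 2 and 3 differ only in the configuration as drawn. Compound 4 `C[C@@H](NC(=O)Nc1cccc(I)c1)c1ccccc1` differs from compound 2 by iodo in place of ethoxycarbonyl on an aromatic carbon. Among the compounds with values here, no measured step isolates this change; compound 1 with 33% only shows that another group at this place can sit far lower. A drop toward that region is therefore expected but uncertain, a number 39 percentage points lower from compound 2 to compound 4 (beyond the scatter). Compound 4 is estimated at 60%, between 25% and 100%.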

Compound 4, a percentage reported as activity, at one concentration (the size of the read-out at that concentration, not a potency): 81%
The estimate for compound 4 lay 21 percentage points below the measured number; measured number inside the range.
By their numbers in this assay, from the lowest: compound 1; then compound 4; then compounds 2 and 3 (each within the scatter of the next).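

In this assay, the aromatic carbon meta to a large group now has a step of its own, with iodo in place of ethoxycarbonyl: a number 18 percentage points lower from compound 2 to compound 4 (beyond the scatter). The step is modest but beyond the scatter, so replacing this ester group with a single iodine atom does change the read-out at this place. Nothing at hand bears on why the number moves.

Open, from the compounds shown here alone, is how other groups at this aromatic carbon would read, such as chloro, an amine or a carboxylic acid. Also open, going by these compounds, is whether a shorter ester, such as methoxycarbonyl, would stay close to compound 2.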